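This account rests on a few compounds, and the source may have more. Where it says the series, first, only, none or still open, it means among the compounds named here.

Of the compounds shown here, three of the shared core have been tested in an assay on HEK293 cells for inhibition of Voltage-dependent T-type calcium channel subunit alpha-1H (Homo sapiens), using a membrane potential dye; a higher number here means a weaker inhibitor, a lower number a stronger inhibitor. Compound 1 `CC[C@H](C)[C@H](NC(=O)N1CCC2(CC1)CN(C1CC1)C2c1ccc(Cl)cc1)C(=O)OC` gives 713 nM, compound 2 `CC[C@H](C)[C@H](NC(=O)N1CCC2(CC1)C(=O)N(c1cccc(F)c1)C2c1ccc(Cl)cc1)C(=O)OC` gives 109 nM, and compound 3 `O=C(Nc1cc(F)cc(F)c1)N1CCC2(CC1)C(=O)N(c1ccc(F)c(Cl)c1)C2c1ccccn1` gives 42 nM, the lowest of the three, with compound 2 the nearest and compound 1 the furthest, both beyond the scatter. Compound 4 `O=C(Nc1cc(F)cc(F)c1)N1CCC2(CC1)C(=O)N(c1cccc(Cl)c1)C2c1ccccn1` differs from compound 3 by hydrogen in place of fluoro on an aromatic carbon. Within the data shown here, no measured pair shows this exact change, so there is no step to lean on. The change removes one heavy atom at the edge of the core, and the expected step from compound 3 to compound 4 in this assay is a 1.3-fold higher number from compound 3 to compound 4 (0.12 log units; within the scatter), no more than the scatter in either direction. Compound 4 is therefore estimated at 55 nM, within 25 nM to 120 nM.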

Compound 4, half-maximal inhibitory concentration: 3490 nM
Beside the measured number, compound 4's estimate is 63-fold (1.80 log units) below it; measured number above the stated range.
By their numbers in this assay, from the lowest: compound 3; then compound 2; then compound 1; then compound 4.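

In this assay, going from 3-chloro-4-fluorophenyl to 3-chlorophenyl gives an 83-fold higher number from compound 3 to compound 4 (1.92 log units; beyond the scatter), so this one aromatic carbon, ortho to a chloro group and para to a large group, is highly sensitive to the loss of fluoro. Among these compounds, the earlier compounds offered no pair differing in one place, so this is the first single-change step on the shared core. Nothing measured here accounts for the size of this step.

Going by these compounds, whether a methoxy, a methyl or a nitrile at this carbon would retain the inhibition of compound 3 stays open. So does whether fluoro has the same weight without the chloro group.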